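From Carbamoyl to Benzoyl: Expecting a Value for Compound 4

A few compounds are considered here, and "the series" means these few. Any claim that something is new, unique, unknown or untested is made for them only; others in the source may bear on it.

Three compounds have been measured in a functional assay on TK-10 cells (Homo sapiens) for inhibition, read by sulforhodamine B assay, with a stated time of 48 h; a higher number here means a weaker inhibitor of growth, a lower number a stronger inhibitor of growth:
compound 1, `N#C/C(=C\N1CCN(C(=O)c2ccco2)C1=S)C(N)=O`, giving 12100 nM
compound 2, `O=CN1CCN(c2ccc(Cl)c(Cl)c2)C1=S`, giving 16500 nM
compound 3, `O=CN1CCN(c2cc(Cl)cc(Cl)c2)C1=S`, giving 15300 nM

Compound 1 has the lowest of these three numbers, but its gap to compound 3 and its gap to compound 2 both fall within the usual scatter of repeated measurements, so the three compounds cannot be told apart on these figures. For the measured compounds named here, compound 2 and compound 3 share a core with compound 1 yet differ from it in more than one place, so no single step between measured compounds is available to lean on.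

Compound 4, `N#C/C(=C\N1CCN(C(=O)c2ccco2)C1=S)C(=O)c1ccccc1`, has not yet been measured in this assay. It differs from compound 1 in one place: phenyl in place of amino on a carbonyl carbon. Going by the values given here, nothing among the measured compounds shows how such a change acts here, so the expected step of a 1.2-fold lower number from compound 1 to compound 4 (0.08 log units; within the scatter) is taken as small, with no direction beyond the scatter. Compound 4 is estimated at 10000 nM, within a range from 3000 nM to 35000 nM.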

Compound 4, concentration for 50% growth inhibition: 10500 nM
Estimate against measurement, compound 4: 1.1-fold (0.02 log units) below; low and high end bracket the measured number.
By their numbers in this assay, from the lowest: compounds 4, 1, 3 and 2 (each within the scatter of the next).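

At this carbonyl carbon, phenyl in place of amino gives a 1.2-fold lower number from compound 1 to compound 4 (0.06 log units; within the scatter) in this assay, so the two compounds cannot be told apart. For the compounds shown here, this is the first comparison here between compounds that differ in only one place, and it shows that replacing one heavy atom with six, adding a six-membered aromatic ring and losing a hydrogen-bond donor, does not move the number beyond the scatter. Nothing available here accounts for this result.

As far as these compounds go, it remains open whether other groups on this carbonyl carbon, such as a dimethylamino group, a methoxy group or a longer alkyl chain, would shift the number beyond the scatter. A single pair also cannot show whether phenyl in place of amino would act the same way on another core.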